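The source may hold more compounds than are shown below. What is called first, only, known or untested is meant among the compounds shown, and "the series" means these compounds.

Measured so far:
- compound 1, `O=Cc1ccc(-c2cnc(C(=O)CCCCCCc3ccccc3)o2)nc1`: 2 nM
- compound 2, `CSC(=O)CCCCc1cnc(C(=O)CCCCCCc2ccccc2)o1`: 1.4 nM

Both numbers come from an assay for inhibition of Fatty-acid amide hydrolase 1 (Rattus norvegicus), using a Dixon plot, with a stated time of 3 h; a higher number here means a weaker inhibitor, a lower number a stronger inhibitor. Compound 1, with 2 nM, has the highest of the two numbers, and its nearest neighbour is compound 2, with a 1.4-fold lower number from compound 1 to compound 2 (0.15 log units; within the scatter); the two values are within the scatter of each other, so no order between them can be claimed.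

Compound 3, `CSCCCCCc1cnc(C(=O)CCCCCCc2ccccc2)o1`, has not yet been measured. It differs from compound 1 in one place: a group of 7 heavy atoms (6 carbon, 1 sulfur; no ring) in place of a group of 8 heavy atoms (6 carbon, 1 nitrogen, 1 oxygen; one six-membered aromatic ring with 1 hetero atom), on an aromatic carbon. Within the data shown here, the one measured step that bears on this change is the one from compound 1 to compound 2, where the same aromatic group on the shared core gave way to an open chain of similar length, and the number moved by a 1.4-fold lower number from compound 1 to compound 2 (0.15 log units; within the scatter), within the scatter. Compound 3 carries a related open chain, so in this assay no step beyond the scatter is expected from compound 1 to compound 3, with a slight lean toward a higher number, a 1.5-fold higher number from compound 1 to compound 3 (0.18 log units; within the scatter). Compound 3 is therefore expected to give about 3 nM, with a likely range from 1 nM to 10 nM.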

Compound 3, inhibition constant: 6.4 nM
For compound 3 the middle estimate is 2.1-fold (0.33 log units) below the measured one; the range from low to high includes it.
By their numbers in this assay, from the lowest: compounds 2 and 1 (each within the scatter of the next); then compound 3.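

In this assay, replacing the aromatic group of compound 1 with the 5-(methylsulfanyl)pentyl chain gives a 3.2-fold higher number from compound 1 to compound 3 (0.51 log units; beyond the scatter), so this change on the aromatic carbon next to the ring oxygen has a readable effect, unlike the earlier swap to the chain of compound 2. The clearest new information comes from the two open chains, where (methylsulfanyl)methyl in place of (methylsulfanyl)carbonyl, four bonds along the chain from an aromatic carbon, gives a 4.6-fold higher number from compound 2 to compound 3 (0.66 log units; beyond the scatter) and shows that having an open chain here does not by itself set the number, since the carbonyl-bearing chain and the chain without it are clearly separated. Nothing measured here explains why this difference appears.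

These three compounds cannot show whether the carbonyl is what matters in itself or whether other chain ends, such as a carboxylic acid, a methyl ester or an amide, would give a similar number. As far as these compounds go, the effect of chain length also remains open, as a longer or shorter chain carrying the same (methylsulfanyl)carbonyl end would be needed to separate length from the chain-end group.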